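The source may hold more compounds than are shown below. What is called first, only, known or untested is meant among the compounds shown, and "the series" means these compounds.

In a functional assay on HeLa cells (Homo sapiens) for antiproliferative activity, read by MTT assay, with a stated time of 72 h (on this read-out lower numbers stand for stronger inhibition and higher numbers for weaker inhibition), compound 3 (`CCC/C=C/C(=O)Nc1cccc(Oc2nc(Nc3ccc(OC)nc3)nc3c2CSCC3)c1`) gives 15300 nM and lies within the scatter of compound 2 (`C=CC(=O)Nc1cccc(Oc2nc(Nc3ccc(OC)nc3)nc3c2CSCC3)c1`) at 26300 nM on the same read-out. Compound 1 (`CC(C)=CC(=O)Nc1cccc(Oc2nc(Nc3ccn(C)n3)nc3c2CSCC3)c1`) shows > 50000 nM as a limit and not as a number. Compound 3 therefore stands among weak values, with no measured gap beyond the scatter between the two numbers available.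

Compound 4 (`COc1ccc(Nc2nc3c(c(Oc4cccc(NC(=O)C=C(C)C)c4)n2)CSCC3)cn1`) has 2-methylprop-1-en-1-yl in place of pent-1-en-1-yl on a carbonyl carbon and is otherwise the same as compound 3. With only a 1.7-fold lower number from compound 2 to compound 3 (0.24 log units; within the scatter) to go on at this place, where pent-1-en-1-yl stands in place of vinyl on a carbonyl carbon, no step beyond the scatter is expected in this assay in either direction. The estimated step is a 1.3-fold higher number from compound 3 to compound 4 (0.12 log units; within the scatter) and is expected to carry no weight of its own. For compound 4 the estimate is 20000 nM with an expected range of 8000 nM to 50000 nM on this read-out.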

Compound 4, half-maximal inhibitory concentration: 29200 nM
Beside the measured number, compound 4's estimate is 1.5-fold (0.16 log units) below it, and the stated range covers the measured number.
By their numbers in this assay, from the lowest: compounds 3, 2 and 4 (each within the scatter of the next). At a limit, above all of these: compound 1.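

At this place on the carbonyl carbon, the measured groups now number three, and 2-methylprop-1-en-1-yl opens no gap beyond the scatter in this assay against either other group (a 1.9-fold higher number from compound 3 to compound 4 (0.28 log units; within the scatter); a 1.1-fold higher number from compound 2 to compound 4 (0.05 log units; within the scatter)). On the nitrogen on an aromatic ring, 6-methoxypyridin-3-yl in place of 1-methyl-1H-pyrazol-3-yl gives only a floor within the scatter (an at least 1.7-fold lower number from compound 1 to compound 4 (0.23 log units; that floor lies within the scatter)). Compound 1 carries > 50000 nM, which is a limit and not a number.

Going by these compounds, whether a group with an amine at the end of the chain, such as 3-(dimethylamino)prop-1-en-1-yl, or a saturated ethyl group on the carbonyl carbon would give a step beyond the scatter stays open. On these data alone, the true size of the step at the aromatic nitrogen also stays open because that comparison rests on a limit: the limit of > 50000 nM in this assay, at which 1 of the 4 values shown sits.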